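This account rests on a few compounds, and the source may have more. Where it says the series, first, only, none or still open, it means among the compounds named here.

Compound 1, `Cc1ccc2cc(C(=O)O)cnc2c1C`: in a functional assay on the whole organism (strain Sprague-Dawley) for inhibition, with Rattus norvegicus as the target (on this read-out higher numbers stand for an effect only at larger amounts of compound and lower numbers for an effect already at smaller amounts), compound 1 gives 25 mg/kg.
Compound 2, `Cc1cccc2c(=O)c(-c3nn[nH]n3)c[nH]c12`: compound 2 gives only a limit of the assay, > 5 mg/kg.
Compound 3, `CSc1cccc2c(=O)c(-c3nn[nH]n3)c[nH]c12`: compound 3 gives 10 mg/kg.

Among the two numbers shown, compound 3 stands at the lowest, and compound 1 at a higher number, a gap beyond the usual scatter. The value of compound 2 is a limit and not a number. Among the compounds with values here, for that reason the only single-point step measured so far, a step that the limit leaves unreadable from compound 2 to compound 3, cannot be read in size, because of the limit of > 5 mg/kg in this assay, at which 1 of the 3 values shown sits.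

Compound 4 is `CC(C)c1cccc2c(=O)c(-c3nn[nH]n3)c[nH]c12`. It differs from compound 3 in one place: isopropyl in place of methylsulfanyl on an aromatic carbon. Within the data shown here, the only measured step at that place is the unreadable one from compound 2 to compound 3, so no measured step gives a readable size for a change here, and none bears on isopropyl at all. The expectation for this assay is therefore a step of no clear direction and modest size, a 1.5-fold higher number from compound 3 to compound 4 (0.18 log units; within the scatter), and the estimate for compound 4 is 15 mg/kg, with a range from 5 mg/kg to 50 mg/kg.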

Compound 4, minimum effective dose: 1.25 mg/kg
Beside the measured number, compound 4's estimate is 12-fold (1.08 log units) above it; measured number below the stated range.
By their numbers in this assay, from the lowest: compound 4; then compound 3; then compound 1.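

Within the data shown here, at this place on an aromatic carbon of the shared core, the exchange of methylsulfanyl for isopropyl gives the first step here that can be read in size in this assay: an 8.0-fold lower number from compound 3 to compound 4 (0.90 log units; beyond the scatter), which lies beyond the usual scatter and shows that the group on this carbon clearly changes the dose needed for an effect. Isopropyl in place of methyl gives an at least 4.0-fold lower number from compound 2 to compound 4 (0.60 log units; beyond the scatter), also beyond the scatter, and the true size of this step stays open because of a single value: the limit of > 5 mg/kg in this assay, at which 1 of the 4 values shown sits. The value of compound 2, > 5 mg/kg, is a limit of the assay and not a number.

The step from methylsulfanyl to isopropyl swaps sulfur for carbon and changes the shape of the group at the same time, so the compounds shown cannot say which of these differences goes with the lower number. Going by these compounds, whether a tert-butyl group, a cyclopropyl ring, a longer chain such as n-propyl, or an amine on this same carbon would lower the number further, or raise it again, also stays open.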